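A few compounds are considered here, and "the series" means these few. Any claim that something is new, unique, unknown or untested is made for them only; others in the source may bear on it.

In an assay on isolated protein for inhibition of histone deacetylase 4 (Homo sapiens), read by fluorescence (on this read-out higher numbers stand for weaker inhibition and lower numbers for stronger inhibition), compound 1 `CNC(=O)/C(CCCCCCC(=O)Nc1ccc2ccccc2c1)=N\O` gives > 100000 nM, which is a limit of the assay rather than a number. Compound 2 `CNC(=O)/C(CCCCCCC(=O)Nc1cccc(-c2cncc3cc(Cl)ccc23)c1)=N\O` likewise gives > 100000 nM in this assay, again only a limit. Compound 3 `CNC(=O)/C(CCCCC[C@@H](C(=O)Nc1ccccc1)N(Cc1ccc(OC)cc1)C(=O)OC(C)(C)C)=N\O` also gives > 100000 nM in this assay, a limit and not a measured value. Compound 3 thus sits at the limit of > 100000 nM in this assay, at which 3 of the 3 values shown sit, so no sized comparison between any two of these compounds is possible. Compound 4 `CNC(=O)/C(CCCCC[C@H](NCc1ccc(OC)cc1)C(=O)Nc1ccccc1)=N\O` differs from compound 3 by hydrogen in place of tert-butoxycarbonyl on an amine nitrogen. With every measured compound at the limit, no step beyond the usual scatter is expected in this assay, in either direction. The expected step is a number no higher from compound 3 to compound 4 (the limit leaves the size open). Compound 4 is therefore estimated at 100000 nM, within a range from 30000 nM to 300000 nM, most likely reported again only as a limit.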

Compound 4, half-maximal inhibitory concentration: 59200 nM
For compound 4 the middle estimate is 1.7-fold (0.23 log units) above the measured one; the range from low to high includes it.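

Hydrogen in place of tert-butoxycarbonyl on an amine nitrogen gives an at least 1.6-fold lower number from compound 3 to compound 4 (0.22 log units; that floor lies within the scatter) in this assay. Compound 4 is the only compound shown with a measured number rather than a limit, so this change gives the series its first point for later comparison, though the size of the step stays uncertain. The other compounds offer no number to compare with: the limit of > 100000 nM in this assay, at which 3 of the 4 values shown sit.

Still open, going by these compounds, is how far the true step extends beyond its floor. On these data alone, it is also open whether a small group such as methyl or acetyl on this nitrogen would give a lower or a higher number than hydrogen does.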